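Aryl change on the triazole nitrogen: compound 4

This account rests on a few compounds, and the source may have more. Where it says the series, first, only, none or still open, it means among the compounds named here.

The series shares one core, and the aryl group on the aromatic nitrogen of the triazole varies. Compound 1 `N#CC1=C(N)Oc2c(c3nc4ccccc4nc3c3ccccc23)C12C(=O)N(Cc1cnnn1-c1ccccc1Br)c1ccccc12` carries a 2-bromophenyl there. In a functional assay on HepG2 cells (Homo sapiens) for antiproliferative activity, read by MTT assay, with a stated time of 48 h (on this read-out lower numbers stand for stronger inhibition and higher numbers for weaker inhibition), compound 1 gives only a limit, > 50000 nM. Compound 2 `N#CC1=C(N)Oc2c(c3nc4ccccc4nc3c3ccccc23)C12C(=O)N(Cc1cnnn1-c1cccc(S(N)(=O)=O)c1)c1ccccc12` carries a 3-sulfamoylphenyl in its place, and in this assay compound 2 gives 21500 nM. For the measured compounds named here, that is the only measured step: an at least 2.3-fold lower number from compound 1 to compound 2 (0.36 log units; beyond the scatter). Compound 3 `COc1ccc(-n2nncc2CN2C(=O)C3(C(C#N)=C(N)Oc4c(N)cc5nc6ccccc6nc5c43)c3ccccc32)cc1` carries a 4-methoxyphenyl and an added amino group on the core. In this assay compound 3 gives only a limit, > 50000 nM. Going by the values given here, compound 3 thus stands at the assay limit (the limit of > 50000 nM in this assay, at which 2 of the 3 values shown sit); no number is known for it, and against compound 2 one can say only that compound 2 returned a number while compound 3 did not.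

Compound 4 `COc1ccc(OC)c(-n2nncc2CN2C(=O)C3(C(C#N)=C(N)Oc4c(N)cc5nc6ccccc6nc5c43)c3ccccc32)c1` is not yet measured. Its change from compound 3: 2,5-dimethoxyphenyl in place of 4-methoxyphenyl on an aromatic nitrogen. The measured step concerns the same aromatic nitrogen but a different pair of groups, so it offers no direct guide to the size of this exchange; it shows only that the aryl on this nitrogen can shift the number by a modest amount. With compound 3 at the limit, no shift beyond the scatter can be read in either direction. Compound 4 is expected to remain near the limit, a step that the limit leaves unreadable from compound 3 to compound 4. The estimate for compound 4 in this assay is 70000 nM, with a range from 25000 nM to 250000 nM.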

Compound 4, half-maximal inhibitory concentration: 45100 nM
For compound 4 the middle estimate is 1.6-fold (0.19 log units) above the measured one; the range from low to high includes it.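

In this assay compound 4 returns a number, 45100 nM, so on the amino-bearing core an aryl group on this aromatic nitrogen can give a reading inside the range of the assay. On these data alone, the step is an at least 1.1-fold lower number from compound 3 to compound 4 (0.04 log units; that floor lies within the scatter); the exchange of 4-methoxyphenyl for 2,5-dimethoxyphenyl therefore cannot be claimed as a change beyond the scatter, and its true size stays unknown. For compound 3 there is only a limit, and the step can be bounded on one side only: the limit of > 50000 nM in this assay, at which 2 of the 4 values shown sit.

Open, as far as these compounds go, is whether a single methoxy group at either position of the 2,5-dimethoxyphenyl would give the same reading, and how a hydroxyl, an amine or a carboxylic acid on that phenyl ring would read in this assay. Also open is what the amino group on the core contributes, as no pair shown differs in that group alone, so the readings on the two cores cannot yet be set against each other.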